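This account rests on a few compounds, and the source may have more. Where it says the series, first, only, none or still open, it means among the compounds named here.

Measured so far in an ADME assay on BaF3 cells (Mus musculus) for antiproliferative activity; on this read-out higher numbers stand for weaker inhibition of growth and lower numbers for stronger inhibition of growth:

Compound 1 `Cc1ccc(NC(=O)c2ccc(C)c(C(F)(F)F)c2)cc1OC1CCN(C(=O)c2ccno2)CC1` gives 8940 nM.
Compound 2 `Cc1ccc(NC(=O)c2cc(Cl)cc(C(F)(F)F)c2)cc1OC1CCN(C(=O)c2cccnc2)CC1` returns only the assay limit > 10000 nM, not a number.
Compound 3 `Cc1ccc(NC(=O)c2cc(Cl)cc(C(F)(F)F)c2)cc1OC1CCN(C(=O)c2ccno2)CC1` likewise returns only the limit > 10000 nM.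

Within the data shown here, compound 2 therefore stands at the limit of > 10000 nM in this assay, at which 2 of the 3 values shown sit; compound 1 is the one compound with a number. The change to compound 4 `Cc1ccc(NC(=O)c2cnc3ccccc3c2)cc1OC1CCN(C(=O)c2cccnc2)CC1` is quinolin-3-yl in place of 3-chloro-5-(trifluoromethyl)phenyl on a carbonyl carbon. Of the measured steps, an at least 1.1-fold higher number from compound 1 to compound 3 (0.04 log units; that floor lies within the scatter) concerns a different exchange and lies within the scatter, and a step that the two limits leave unreadable from compound 2 to compound 3 concerns the 1,2-oxazol-5-yl for pyridin-3-yl exchange and cannot be read. Neither bears directly on a quinolin-3-yl amide, so no step beyond the scatter is expected in this assay . Compound 4 is estimated at 9000 nM, range 2000 nM to 40000 nM, an expected step of an at least 1.1-fold lower number from compound 2 to compound 4 (0.04 log units; that floor lies within the scatter), with a fair chance of again only a limit.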

Compound 4, concentration for 50% growth inhibition: > 10000 nM
Compound 4 gave a limit, no number (the forecaster's own chance of this, stated with the estimate: 55%); middle value at least 1.1-fold (0.04 log units) away from the limit.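

In this assay compound 4, like compound 2, returns only a limit, so no step between compound 2 and compound 4 can be read: the limit of > 10000 nM in this assay, at which 3 of the 4 values shown sit.

Going by these compounds, whether quinolin-3-yl differs from 3-chloro-5-(trifluoromethyl)phenyl on that carbonyl carbon in this assay stays open.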